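The compounds below may be only part of what the source reports. "The series", "measured", "known", "first", "only" and "open" are said of these compounds alone.

Compound 3 `c1cc(-c2nccs2)c2c(c1)C(c1ncc[nH]1)CC2` was tested in a functional assay on CHO cells for agonist activity at Alpha-1B adrenergic receptor (Homo sapiens), read by FLIPR and calcium flux (a lower number here means that less compound is needed, a higher number that more compound is needed for the effect), where it gives only a limit, > 10000 nM. The same limit, (the limit of > 10000 nM in this assay, at which 3 of the 3 values shown sit), holds for compound 1 `CCCS(=O)(=O)Nc1cccc2c1CCC2c1ncc[nH]1`, which gives > 10000 nM. Compound 2 `COc1c(Cl)ccc2c1CCC2c1ncc[nH]1` likewise reaches only the limit, > 10000 nM. Compound 4 `CCS(=O)(=O)Nc1cccc2c1CCC2c1ncc[nH]1` has not yet been measured; it differs from compound 3 by (ethylsulfonyl)amino in place of 1,3-thiazol-2-yl on an aromatic carbon. Among the compounds with values here, the one measured step at this position, a step that the two limits leave unreadable from compound 1 to compound 3, has limits at both ends and so shows no size. Compound 1 carries (propylsulfonyl)amino at this place and gives > 10000 nM, a limit. On that ground the step is expected to be a step that the limit leaves unreadable from compound 3 to compound 4, nothing beyond the scatter. Compound 4 is therefore expected to give about 20000 nM, between 5000 nM and 100000 nM, most likely again only a limit.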

Compound 4, half-maximal effective concentration: > 10000 nM
Compound 4: only a limit was reported; the forecaster's own chance of this, stated with the estimate: 85%; the middle value is on the limit's open side.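

Compound 1, compound 3 and compound 4 all give only a limit in this assay, so no new step can be read among them: the limit of > 10000 nM in this assay, at which 4 of the 4 values shown sit.

The compounds shown leave open whether any of them has a measurable effect in this assay, and how large these steps are.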